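The source may hold more compounds than are shown below. What is called first, only, known or untested is meant among the compounds shown, and "the series" means these compounds.

Compound 1 `COc1ccc(C(=O)Nc2cccc(-c3ccnc4c(NC(C)=O)cccc34)c2)cc1OC`, compound 2 `CC(=O)Nc1cccc2c(-c3cccc(NC(=O)c4ccc(F)c(C(F)(F)F)c4)c3)ccnc12` and compound 3 `CC(=O)Nc1cccc2c(-c3cccc(NC(=O)c4ccc(Cl)cc4C(F)(F)F)c3)ccnc12` share one core and differ only in the ring on the carbonyl carbon. In a functional assay on A375P cells (Homo sapiens) for antiproliferative activity, read by MTT assay, with a stated time of 48 h (a higher number here means a weaker inhibitor, a lower number a stronger inhibitor), compound 1 gives 5300 nM and compound 2 gives 6800 nM. Compound 3 reaches only a limit of the assay, > 20000 nM, and so stands without a number of its own. The steps of an at least 3.7-fold higher number from compound 1 to compound 3 (0.57 log units; beyond the scatter) and an at least 2.9-fold higher number from compound 2 to compound 3 (0.46 log units; beyond the scatter) mark it as the weakest of the three. Compound 4 `CC(=O)Nc1cccc2c(-c3cccc(NC(=O)c4cc5ccccc5s4)c3)ccnc12` brings a new ring: 1-benzothiophen-2-yl in place of 4-chloro-2-(trifluoromethyl)phenyl on a carbonyl carbon. For the measured compounds named here, no measured step covers this ring, but the numbers of compound 1 at 5300 nM and compound 2 at 6800 nM suggest that other rings on this carbon do give numbers. Compound 4 is therefore expected to land near 7000 nM, within 2000 nM to 25000 nM. The step expected is an at least 2.8-fold lower number from compound 3 to compound 4 (0.45 log units; beyond the scatter).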

Compound 4, half-maximal inhibitory concentration: 9100 nM
The estimate for compound 4 lay 1.3-fold (0.11 log units) below the measured number, within the range that was stated.
By their numbers in this assay, from the lowest: compounds 1, 2 and 4 (each within the scatter of the next). At a limit, above all of these: compound 3.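

On this carbonyl carbon in this assay, the two-ring 1-benzothiophen-2-yl group gives a number on a par with the single phenyl rings, as the steps of a 1.3-fold higher number from compound 2 to compound 4 (0.13 log units; within the scatter) and a 1.7-fold higher number from compound 1 to compound 4 (0.23 log units; within the scatter) show no real difference. Among these four compounds, the 4-chloro-2-(trifluoromethyl)phenyl ring alone stands apart, with an at least 2.1-fold lower number from compound 3 to compound 4 (0.34 log units; beyond the scatter) on replacing it. Compound 3 stands at a limit, so that step gives only a minimum size: the limit of > 20000 nM in this assay, at which 1 of the 4 values shown sits.

On these data alone, what stays open is the true value of compound 3, and whether a ring carrying an amine or a carboxylic acid on this carbon would give a lower number.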